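A few compounds are considered here, and "the series" means these few. Any claim that something is new, unique, unknown or untested is made for them only; others in the source may bear on it.

Compound 2 `C=C1C(=O)Oc2cc(OC)ccc2C1CCCC` stands lowest of the two numbers measured in a functional assay on NALM-6 cells (Homo sapiens) for cytotoxicity, read by MTT assay, with a stated time of 48 h (on this read-out higher numbers stand for weaker inhibition and lower numbers for stronger inhibition), where compound 2 gives 6200 nM. Compound 1 `C=C1C(=O)Oc2cc(OC)ccc2C1C` gives 53600 nM in this assay. The two are separated by an 8.6-fold lower number from compound 1 to compound 2 (0.94 log units; beyond the scatter), the change being propyl in place of hydrogen on a saturated chain carbon bound to a saturated ring carbon. Compound 3 `C=C1C(=O)Oc2cc(OC)ccc2C1C(C)C` has not yet been measured. It differs from compound 2 by isopropyl in place of butyl on a saturated ring carbon. Going by the values given here, the only step bearing on this change is an 8.6-fold lower number from compound 1 to compound 2 (0.94 log units; beyond the scatter), in which a longer chain at this place went with a markedly lower number. Isopropyl carries fewer carbons than butyl yet more than methyl, so an intermediate result seems plausible. Compound 3 is therefore expected to show a step of a 2.4-fold higher number from compound 2 to compound 3 (0.38 log units; beyond the scatter). Compound 3 is estimated at 15000 nM, with a likely range from 5000 nM to 45000 nM.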

Compound 3, half-maximal inhibitory concentration: 850 nM
Estimate against measurement, compound 3: 18-fold (1.25 log units) above; the measured number lies below the stated range.
By their numbers in this assay, from the lowest: compound 3; then compound 2; then compound 1.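

In this assay, the earlier pair suggested that a longer chain on this saturated ring carbon simply goes with a lower number, but the step of a 7.3-fold lower number from compound 2 to compound 3 (0.86 log units; beyond the scatter), with isopropyl in place of butyl, breaks that reading. Heavy-atom count alone does not order these groups: isopropyl has 3 heavy atoms and butyl has 4, yet isopropyl gives the lowest number of the series, and the step of a 63-fold lower number from compound 1 to compound 3 (1.80 log units; beyond the scatter) shows how far it stands from methyl. Nothing available here explains why this branched group gives the lowest number.

Three compounds cannot separate the effect of branching from that of chain length. On these data alone, it remains open whether a cyclopropyl or tert-butyl group would lower the number further, and whether a longer chain such as hexyl would raise it.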